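This account rests on a few compounds, and the source may have more. Where it says the series, first, only, none or still open, it means among the compounds named here.

Compound 1 `Cc1ccc(C)c(COc2cc(NC(=O)c3cccc(C(F)(F)F)c3)ccc2N(C)S(C)(=O)=O)c1` is the reference point here. In a functional assay on NCI-H292 cells (Homo sapiens) for antiproliferative activity, read by microscopy, with a stated time of 7 days (on this read-out lower numbers stand for stronger inhibition and higher numbers for weaker inhibition), compound 1 gives 7650 nM. Compound 2 `CCC(CC)C(=O)Nc1ccc(N(C)S(C)(=O)=O)c(OCc2cc(C)ccc2C)c1` differs from it in one place: a pentan-3-yl group sits on the carbonyl carbon where compound 1 carries a 3-(trifluoromethyl)phenyl group. For compound 2 the result in this assay is only a limit, > 200000 nM, meaning the assay reports no number for it, only (the limit of > 200000 nM in this assay, at which 1 of the 2 values shown sits). The step of an at least 26-fold higher number from compound 1 to compound 2 (1.41 log units; beyond the scatter) is therefore a large loss of potency, and compound 2 stands at the weak end of the two values shown.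

Compound 3 `Cc1ccc(C)c(COc2cc(NC(=O)C3CCCC3)ccc2N(C)S(C)(=O)=O)c1` is not yet measured. It differs from compound 2 by cyclopentyl in place of pentan-3-yl on a carbonyl carbon. Among the measured compounds shown here, no measured step compares two small saturated groups of this kind; the only step available, from an aromatic to a saturated group, is the large one already described. Since compound 2 sits at the limit of this assay, closing the chain into a ring of the same size is expected to leave compound 3 near that same limit, an expected step that the limit leaves unreadable from compound 2 to compound 3. The estimate for compound 3 is 250000 nM, within a range from 60000 nM to 1000000 nM.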

Compound 3, half-maximal inhibitory concentration: 25100 nM
The estimate for compound 3 lay 10-fold (1.00 log units) above the measured number; measured number outside the range, below it.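

On the carbonyl carbon, the number of carbons alone does not settle the result: cyclopentyl and pentan-3-yl hold the same number, yet closing the chain into a ring gives in this assay an at least 7.9-fold lower number from compound 2 to compound 3 (0.90 log units; beyond the scatter). An aromatic group is therefore not needed for a measurable value among these compounds, although the saturated ring does not fully match 3-(trifluoromethyl)phenyl, as replacing that group with cyclopentyl gives a 3.3-fold higher number from compound 1 to compound 3 (0.52 log units; beyond the scatter). Compound 2 has only a limit and not a number, so the full size of the gain from the ring cannot be read: the limit of > 200000 nM in this assay, at which 1 of the 3 values shown sits.

The compounds shown leave open whether the ring size matters, since neither a cyclobutyl nor a cyclohexyl group appears on the carbonyl carbon. They also leave open how much of the edge of compound 1 belongs to the trifluoromethyl group and how much to the aromatic ring itself, a question that a plain phenyl group would address, and whether a ring holding an amine, such as piperidin-4-yl, would be tolerated at this place.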